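Working notes on a nucleoside prodrug series, compound 4 ahead

The compounds below may be only part of what the source reports. "The series", "measured", "known", "first", "only" and "open" are said of these compounds alone.

Measured so far in an in vivo ADME assay on the whole organism (Huh-7 cells, Homo sapiens) for pharmacokinetics, read by LC-MS, with a stated time of 24 h, tested at 10 uM, at a dose of 10 uM; a higher number here means more compound in the circulation at the dose given, a lower number less compound in the circulation:
- compound 1 `C#C[C@@]1(c2ccc3c(N)ncnn23)O[C@H](CO)[C@@H](O)[C@H]1O` gives 0.00066 nM
- compound 2 `CC(C)(C)C(=O)SCCOP(=O)(OCCSC(=O)C(C)(C)C)OC[C@H]1O[C@@](C#N)(c2ccc3c(N)ncnn23)[C@H](O)[C@@H]1O` gives 4.22 nM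
- compound 3 `C=C[C@@]1(c2ccc3c(N)ncnn23)O[C@H](COP(=O)(OCCSC(=O)C(C)(C)C)OCCSC(=O)C(C)(C)C)[C@@H](O)[C@H]1O` gives 0.44 nM

Compound 3 stands second highest of the three numbers: nearest is compound 2, which is beyond the scatter above it, and furthest is compound 1, far below it and likewise beyond the scatter. For the measured compounds named here, the only single-place step measured is a 9.6-fold lower number from compound 2 to compound 3 (0.98 log units; beyond the scatter), a modest change on a saturated ring carbon.

Compound 4 `C#C[C@@]1(c2ccc3c(N)ncnn23)O[C@H](COP(=O)(OCCSC(=O)C(C)(C)C)OCCSC(=O)C(C)(C)C)[C@@H](O)[C@H]1O` differs from compound 3 by ethynyl in place of vinyl on a saturated ring carbon. Going by the values given here, no measured step exchanges vinyl for ethynyl, so the step from compound 2 to compound 3 is the only one that bears on this change, and it does so only loosely, since it concerns cyano rather than ethynyl. On that basis the change is expected to move the number by no more than the modest size seen there, in either direction, and a result within the scatter of compound 3 is the most likely. The estimate for compound 4 is therefore 0.5 nM, with a range of 0.1 nM to 2.5 nM, which corresponds to an expected step of a 1.1-fold higher number from compound 3 to compound 4 (0.06 log units; within the scatter).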

Compound 4, maximal plasma concentration: 0.15 nM
Compound 4: middle estimate off by 3.3-fold (0.52 log units), on the high side; the range from low to high includes it.
By their numbers in this assay, from the lowest: compound 1; then compound 4; then compound 3; then compound 2.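

On the saturated ring carbon next to the ring oxygen, ethynyl in place of vinyl gives a 2.9-fold lower number from compound 3 to compound 4 (0.47 log units; beyond the scatter) in this assay and so shows that these two groups, with the same heavy-atom count, are not interchangeable at this position. Ethynyl in place of cyano gives a 28-fold lower number from compound 2 to compound 4 (1.45 log units; beyond the scatter) and extends the earlier step of a 9.6-fold lower number from compound 2 to compound 3 (0.98 log units; beyond the scatter) into an order of cyano, then vinyl, then ethynyl across compound 2, compound 3 and compound 4. Nothing on hand bears on what lies behind this order.

The compounds shown leave open where a methyl, an aminomethyl or a longer chain such as propyl would fall in this order at the same carbon. Three groups on one shared core also cannot show whether the order holds with other groups elsewhere on the molecule.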